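Series notes: from compound 3 to the unmeasured compound 4

The compounds below may be only part of what the source reports. "The series", "measured", "known", "first", "only" and "open" are said of these compounds alone.

Compound 1 `CC1(C)S[C@@H]2/C(=C\C(=O)c3ccco3)C(=O)N2[C@H]1C(=O)OC(c1ccccc1)c1ccccc1`: in a functional assay on HT-1080 cells (Homo sapiens) for cytotoxicity, read by MTT assay, with a stated time of 48 h (on this read-out higher numbers stand for weaker inhibition and lower numbers for stronger inhibition), compound 1 gives 45500 nM.
Compound 2 `CC(=O)/C=C1\C[C@H]2SC(C)(C)[C@H](C(=O)OC(c3ccccc3)c3ccccc3)N2C1=O`: in this assay compound 2 gives > 100000 nM, which is a limit of the assay and not a number.
Compound 3 `CCOC(=O)/C=C1/C(=O)N2[C@@H]1SC(C)(C)[C@@H]2C(=O)OC(c1ccccc1)c1ccccc1`: in this assay compound 3 gives 25100 nM.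

Compound 3 holds the lowest of the two numbers in this assay; the nearest is compound 1, and the step of a 1.8-fold lower number from compound 1 to compound 3 (0.26 log units; within the scatter) separates them. The third value is a limit (the limit of > 100000 nM in this assay, at which 1 of the 3 values shown sits).

Compound 4 `CC(=O)/C=C1/C(=O)N2[C@@H]1SC(C)(C)[C@@H]2C(=O)OC(c1ccccc1)c1ccccc1` differs from compound 3 by methyl in place of ethoxy on a carbonyl carbon. Among the compounds with values here, only one measured step touches this carbonyl carbon, a 1.8-fold lower number from compound 1 to compound 3 (0.26 log units; within the scatter), where one substituent replaced another without leaving the scatter. Compound 2, which also carries an acetyl group, gives only a limit. Taking both together, a modest move toward weaker inhibition is expected, with the step of a 1.6-fold higher number from compound 3 to compound 4 (0.20 log units; within the scatter) possibly within the scatter. Compound 4 is therefore estimated at 40000 nM, in the range 15000 nM to 100000 nM.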

Compound 4, half-maximal inhibitory concentration: 20800 nM
Compound 4: middle estimate off by 1.9-fold (0.28 log units), on the high side; low and high end bracket the measured number.
By their numbers in this assay, from the lowest: compounds 4, 3 and 1 (each within the scatter of the next, the first and the last beyond it). At a limit, above all of these: compound 2.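

On the carbonyl carbon whose other neighbour is the double-bonded chain carbon, ethoxycarbonyl and acetyl are not told apart in this assay with a 1.2-fold lower number from compound 3 to compound 4 (0.08 log units; within the scatter) as the printed step. A step at this carbon now leaves the scatter, though only modestly, with a 2.2-fold lower number from compound 1 to compound 4 (0.34 log units; beyond the scatter) for methyl in place of furan-2-yl, while compound 3 stays within the scatter of both compound 1 and compound 4. No measurement shown here accounts for these steps.

From the compounds shown here alone, whether a dimethylamino group or a longer chain such as butyl on this carbonyl carbon would stay within the same narrow band remains open. Also open, going by these compounds, is whether a carboxylic acid in place of the ester elsewhere on the shared core would alter the numbers of compound 3 or compound 4.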